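Methyl on the pyridyl ether of compound 3

The compounds below may be only part of what the source reports. "The series", "measured", "known", "first", "only" and "open" are said of these compounds alone.

Measured so far in a functional assay with metabotropic glutamate receptor 5 (Homo sapiens) as the target, read by FLIPR; on this read-out higher numbers stand for weaker inhibition and lower numbers for stronger inhibition:
Compound 1 `COc1cccc(OCC#Cc2cc(C)ccn2)c1` gives > 10000 nM, a limit of the assay.
Compound 2 `Cc1cccc(C#CCOc2cccc(Cl)c2)n1` gives 101 nM.
Compound 3 `Cc1cccc(C#CCOc2cccnc2)n1` gives > 10000 nM, a limit of the assay.

Compound 3 stands among the values only as a limit; no number is known for it. Compound 1 sits at the same limit, so these two cannot be ordered against each other. Within the data shown here, compound 2 is the one value read as a number in this assay.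

Compound 4 `Cc1ccc(OCC#Cc2cccc(C)n2)cn1` is compound 3 with one change: methyl in place of hydrogen on an aromatic carbon, on the six-membered aromatic ring with one nitrogen, next to the ring nitrogen and para to a large group. Among the measured compounds shown here, no measured step of this kind stands in the set, so no size can be read for it. The expectation is that compound 4 stays near the limit where compound 3 sits, with the step from compound 3 to compound 4 estimated as an at least 1.2-fold lower number from compound 3 to compound 4 (0.09 log units; that floor lies within the scatter). For compound 4 the estimate in this assay is 8000 nM, within 1500 nM to 50000 nM.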

Compound 4, half-maximal inhibitory concentration: 2490 nM
Estimate against measurement, compound 4: 3.2-fold (0.51 log units) above; the measured number falls inside the stated range.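

In this assay, methyl in place of hydrogen on an aromatic carbon, next to the ring nitrogen and para to a large group, gives an at least 4.0-fold lower number from compound 3 to compound 4 (0.60 log units; beyond the scatter). This single added methyl brings the pyridyl ether off the limit and onto a readable number, so this position accepts the change and the series can be followed there. The step is only a floor, because compound 3 carries a limit and no number: the limit of > 10000 nM in this assay, at which 2 of the 4 values shown sit.

Going by these compounds, the full size of the step stays open for as long as compound 3 has no number. Also open, on these data alone, is whether the effect belongs to methyl itself or would hold for an ethyl, a methoxy or a fluorine at the same place, and whether a methyl on another aromatic carbon of this ring would do the same.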